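Three Measured Compounds and One Still Awaiting Its Value

The compounds below may be only part of what the source reports. "The series", "measured", "known", "first", "only" and "open" are said of these compounds alone.

In a functional assay on MCF7 cells (Homo sapiens) for cytotoxicity, read by MTT assay, with a stated time of 72 h (on this read-out lower numbers stand for stronger inhibition and higher numbers for weaker inhibition), the measured compounds stand as follows. Compound 1 `Cc1cc(=O)n(-c2ccccc2OC(F)(F)F)nc1C(=O)Nc1ccc(Oc2ncnc3[nH]ccc23)cc1` gives 32000 nM. Compound 2 `Cc1cc(=O)n(-c2ccc(Br)cc2F)nc1C(=O)Nc1ccc(Oc2ncnc3[nH]ccc23)cc1` gives 3210 nM. Compound 3 `Cc1cc(=O)n(-c2ccccc2OC(F)(F)F)nc1C(=O)Nc1ccc(Oc2ncnc3c2ccn3C)c(F)c1` gives > 60000 nM, which is a limit of the assay and not a number.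

The change from compound 1 to compound 2 is 4-bromo-2-fluorophenyl in place of 2-(trifluoromethoxy)phenyl on an aromatic nitrogen; it brought a 10-fold lower number from compound 1 to compound 2 (1.00 log units; beyond the scatter). Compound 4 `Cc1cc(=O)n(-c2ccc(Br)cc2F)nc1C(=O)Nc1ccc(Oc2ncnc3c2ccn3C)c(F)c1` has not been measured; it differs from compound 3 by 4-bromo-2-fluorophenyl in place of 2-(trifluoromethoxy)phenyl on an aromatic nitrogen, the same kind of change. How the core of compound 3 differs from the core of compound 1 is not broken down here. Because compound 3 sits at the limit of > 60000 nM in this assay, at which 1 of the 3 values shown sits, no numerical starting point exists for its step. Compound 4 is nonetheless expected to reach about 15000 nM in this assay, with a plausible range from 4000 nM to 60000 nM. The expected step of an at least 4.0-fold lower number from compound 3 to compound 4 (0.60 log units; beyond the scatter) carries a real chance of again being reported only as a limit. That expectation rests on a 10-fold lower number from compound 1 to compound 2 (1.00 log units; beyond the scatter) and on the limit of compound 3.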

Compound 4, half-maximal inhibitory concentration: > 60000 nM
Compound 4 gave a limit, no number (the forecaster's own chance of this, stated with the estimate: 35%); middle value at least 4.0-fold (0.60 log units) away from the limit.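

In this assay compound 3 and compound 4 both give a limit and not a number, so no step between them can be read: the limit of > 60000 nM in this assay, at which 2 of the 4 values shown sit.

The compounds shown leave open whether 4-bromo-2-fluorophenyl in place of 2-(trifluoromethoxy)phenyl changes the number at all on the core of compound 3.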